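This account rests on a few compounds, and the source may have more. Where it says the series, first, only, none or still open, it means among the compounds named here.

Measured compounds:
- compound 1, `CC(C)(C)OC(=O)N1CCC[C@H]1C(=O)N1CCC(NS(=O)(=O)c2cc(S(=O)(=O)c3ccccc3)ccc2C(F)(F)F)CC1`: in an assay on isolated protein for binding affinity to secreted frizzled-related protein 1 (Homo sapiens), read by fluorescence (a higher number here means a weaker inhibitor, a lower number a stronger inhibitor), compound 1 gives 60 nM
- compound 2, `CC(C)(C)OC(=O)N1CCC[C@@H]1C(=O)N1CCC(NS(=O)(=O)c2cc(S(=O)(=O)c3ccccc3)ccc2C(F)(F)F)CC1`: in this assay compound 2 gives 120 nM

Going by the values given here, compound 1 gives the lower of the two numbers, but its only neighbour sits within the usual scatter: a 2.0-fold higher number from compound 1 to compound 2 (0.30 log units; within the scatter). That single measured step separates two compounds that differ only in configuration as drawn (the fact that compounds 1 and 2 differ only in the configuration as drawn), so it says nothing about exchanging a group on the carbonyl carbon.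

Compound 3, `CC(C)(C)NC(=O)N1CCC[C@H]1C(=O)N1CCC(NS(=O)(=O)c2cc(S(=O)(=O)c3ccccc3)ccc2C(F)(F)F)CC1`, is unmeasured. It differs from compound 1 in one place: (tert-butyl)amino in place of tert-butoxy on a carbonyl carbon. Among the compounds with values here, no measured pair shows an exchange of this kind, so the expectation rests on the number of compound 1 alone, and a step beyond the scatter is not expected in either direction in this assay. Compound 3 is expected to give 70 nM in this assay, within 20 nM to 250 nM. That estimate means a 1.2-fold higher number from compound 1 to compound 3 (0.07 log units; within the scatter).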

Compound 3, half-maximal inhibitory concentration: 20 nM
Compound 3: middle estimate off by 3.5-fold (0.54 log units), on the high side; low and high end bracket the measured number.
By their numbers in this assay, from the lowest: compound 3; then compounds 1 and 2 (each within the scatter of the next).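

Going by these compounds alone, the group on the carbonyl carbon matters in this assay: (tert-butyl)amino in place of tert-butoxy gives a 3.0-fold lower number from compound 1 to compound 3 (0.48 log units; beyond the scatter), the first step here to lie beyond the scatter. The exchange keeps the heavy-atom count and trades a hydrogen-bond acceptor for a hydrogen-bond donor, although these counts alone do not show what drives the step. The larger step, a 6.0-fold lower number from compound 2 to compound 3 (0.78 log units; beyond the scatter), includes a change of drawn configuration as well as the change of group, so it does not show the effect of the exchange alone: the fact that compounds 1 and 2 differ only in the configuration as drawn

Still open, as far as these compounds go, is how other groups on this carbonyl carbon, such as methylamino, dimethylamino or a plain methyl, would compare with (tert-butyl)amino. Also open, from the compounds shown here alone, is whether the opposite configuration at the saturated ring carbon would change the number when (tert-butyl)amino is in place.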